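The source may hold more compounds than are shown below. What is called first, only, known or untested is meant among the compounds shown, and "the series" means these compounds.

Values in an ADME assay on HEK293 cells (Homo sapiens) for inhibition, read by MTT assay, with a stated time of 96 h; on this read-out higher numbers stand for weaker inhibition of growth and lower numbers for stronger inhibition of growth
- compound 1 (`O=C(OCc1ccccc1)SCCCCCCNC(=O)c1cc(-c2ccncc2)n[nH]1`) : 19700 nM
- compound 2 (`C=CCOC(=O)SCCCCCCNC(=O)c1cc(-c2ccncc2)n[nH]1`) : 27500 nM
- compound 3 (`CCCCCCCC/C=C\CCCCCCCC(=O)SCCCCCCNC(=O)c1cc(-c2ccncc2)n[nH]1`) : > 50000 nM, a limit and not a number

Going by the values given here, compound 2 holds one of only two numbers, and that number lies within the scatter of the other. Compound 4 (`CSCCCCCCNC(=O)c1cc(-c2ccncc2)n[nH]1`) differs from compound 2 by methyl in place of allyloxycarbonyl on a sulfur. Among the compounds with values here, no measured step makes this exchange. The nearest evidence is a 1.4-fold higher number from compound 1 to compound 2 (0.14 log units; within the scatter), a change further out in the group that leaves here. No step beyond the scatter is therefore expected in this assay, and the estimated step is a 1.3-fold higher number from compound 2 to compound 4 (0.10 log units; within the scatter). For compound 4 the expected value is 35000 nM, with an estimated range from 15000 nM to 80000 nM.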

Compound 4, concentration for 50% growth inhibition: > 50000 nM
Compound 4: a limit, no number; the forecaster's own chance of this, stated with the estimate: 45%; middle value at least 1.4-fold (0.15 log units) from the limit.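

In this assay, going by these compounds alone, replacing the whole benzyloxycarbonyl group on the sulfur with methyl gives the first step beyond the scatter: an at least 2.5-fold higher number from compound 1 to compound 4 (0.40 log units; beyond the scatter). With allyloxycarbonyl as the group that leaves, the same change gives an at least 1.8-fold higher number from compound 2 to compound 4 (0.25 log units; that floor lies within the scatter), so this pair alone does not establish a loss of growth inhibition. The full size of both steps stays unresolved: the limit of > 50000 nM in this assay, at which 2 of the 4 values shown sit.

Still open, from the compounds shown here alone, is how a free thiol, an acetyl group or a longer alkyl chain on this sulfur would read in this assay.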